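The compounds below may be only part of what the source reports. "The series", "measured", "known", "first", "only" and "open" are said of these compounds alone.

Compound 1 `CCCOc1ccc(C(=O)/C=C/c2ccc(C(=O)Nc3cccc(-c4cc(C(=O)OC)no4)c3)cc2)cc1` gives > 40 ug/mL in an ADME assay on Vero cells (Chlorocebus sabaeus) for cytotoxicity, read by MTT assay, with a stated time of 72 h (on this read-out lower numbers stand for higher toxicity in this test and higher numbers for lower toxicity in this test), a limit rather than a number.
Compound 2 `COC(=O)c1cc(-c2cccc(NC(=O)c3ccc(/C=C/C(=O)c4ccc(OC)cc4)cc3)c2)on1` gives > 10 ug/mL in this assay, also a limit.
Compound 3 `COC(=O)c1cc(-c2cccc(NC(=O)c3ccc(/C=C/C(=O)c4ccc(OC)c([N+](=O)[O-])c4)cc3)c2)on1` gives > 40 ug/mL in this assay, again a limit.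

Compound 3 therefore stands only at a limit, as do the other two values; two sit at the limit of > 40 ug/mL in this assay, at which 2 of the 3 values shown sit, and one at the limit of > 10 ug/mL in this assay, at which 1 of the 3 values shown sits. Compound 4 `COC(=O)c1cc(-c2cccc(NC(=O)c3ccc(/C=C/C(=O)c4ccc(CC(C)C)cc4)cc3)c2)on1` differs from compound 3 by 4-isobutylphenyl in place of 4-methoxy-3-nitrophenyl on a carbonyl carbon. Among the measured compounds shown here, the steps that bear on this change are a step that the two limits leave unreadable from compound 1 to compound 3 and a step that the two limits leave unreadable from compound 2 to compound 3, both left unreadable by the limits, so no direction can be read from them. The step of an at least 1.3-fold lower number from compound 3 to compound 4 (0.12 log units; that floor lies within the scatter) is thus only a guess, and compound 4 is expected to give 30 ug/mL in this assay, within 8 ug/mL to 80 ug/mL.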

Compound 4, half-maximal cytotoxic concentration: > 10 ug/mL
Compound 4: only a limit was reported; the forecaster's own chance of this, stated with the estimate: 50%; the middle value is on the limit's open side.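

Among the compounds shown here, compound 4, like compound 1, compound 2 and compound 3, is reported only as a limit in this assay, and no step to compound 4 can be read. The compounds shown leave open where any actual value lies.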